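Lipophilicity of a sulfonamide series: from compound 1 to compound 4

This account rests on a few compounds, and the source may have more. Where it says the series, first, only, none or still open, it means among the compounds named here.

The measured compounds and their values in a physicochemical assay for lipophilicity, at pH 7.4 (a higher number here means a more lipophilic compound, a lower number a more polar compound), are:
compound 1, `CC(C)CN(Cc1ccccc1C(F)(F)F)S(=O)(=O)c1ccc2c(c1)C(O)CC(C1CCOCC1)O2`, distribution coefficient 4.23;
compound 2, `CCc1ccc(N(CC2CCC2)S(=O)(=O)c2ccc3c(c2)C(O)CC(C2CCOCC2)O3)cc1`, distribution coefficient 4.01;
compound 3, `CCc1ccc(N(CC(C)C)S(=O)(=O)c2ccc3c(c2)CCC3OC2CCOCC2)cc1`, distribution coefficient 4.96.

Among these three numbers compound 1 stands second highest. Compound 2 lies close to it, within the usual scatter of this assay, so the two cannot be ranked against each other. Compound 3 gives a number clearly higher than compound 1, beyond the scatter.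

Compound 4, `Cc1ccc(N(CC(C)C)S(=O)(=O)c2ccc3c(c2)C(O)CC(C2CCOCC2)O3)c(C)c1`, has not been measured. It differs from compound 1 in one place: 2,4-dimethylphenyl in place of 2-(trifluoromethyl)benzyl on a sulfonamide nitrogen. Going by the values given here, no step between two measured compounds mirrors this exchange, so the expectation rests on the spread of the three measured values and on the smaller group that enters.

Compound 4 is expected to sit somewhat lower than compound 1 in this assay, the estimated step being a number 0.33 log units lower from compound 1 to compound 4 (beyond the scatter), a modest decrease that may just reach beyond the scatter. The estimate for compound 4 is 3.9, with a range from 3.5 to 4.3.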

Compound 4, distribution coefficient: 4.19
Estimate against measurement, compound 4: 0.29 log units below; low and high end bracket the measured number.
By their numbers in this assay, from the lowest: compounds 2, 4 and 1 (each within the scatter of the next); then compound 3.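

In this assay, going by these compounds alone, 2,4-dimethylphenyl in place of 2-(trifluoromethyl)benzyl on a sulfonamide nitrogen gives a number 0.04 log units lower from compound 1 to compound 4 (within the scatter), the first step at this position that can be read directly. The entering group has fewer heavy atoms and no fluorine, while both groups hold one six-membered aromatic ring of carbon only, and compound 1 and compound 4 still cannot be ranked against each other in this assay. No measurement given here bears on the reason for this result.

Within the data shown here, this single pair compares only two carbon-ring groups, so it remains open whether an amine or a carboxylic acid on that ring would also give a step within the scatter. As far as these compounds go, it is equally open whether the exchange would read the same with a longer chain as the saturated chain on that nitrogen.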